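The source may hold more compounds than are shown below. What is called first, only, known or untested is meant among the compounds shown, and "the series" means these compounds.

Compound 1 `CC1C(=O)CC(c2ccc(F)cc2)N(C(=O)CN2CCN(C)CC2)C1c1ccc(Cl)cc1` gives 65.5% in a functional assay on the whole organism for inhibition, with Mus musculus as the target, in the writhing test, with a stated time of 1 h, at a dose of 60 mg/kg by the oral route; a lower number here means less inhibition, a higher number more inhibition at the dose given (going by the name of the read-out).
Compound 2 `COc1ccc(C2C(C)C(=O)CC(c3ccc(Cl)cc3)N2C(=O)CN2CCN(C)CC2)cc1` gives 53.1% in this assay.
Compound 3 `COc1ccc(C2C(C)C(=O)CC(c3ccc(F)cc3)N2C(=O)CCl)cc1` gives 51.2% in this assay.

Among these three numbers, compound 3 has the lowest. Its distance to compound 2 lies within the scatter of repeated measurements, so the two cannot be told apart on this evidence. Its distance to compound 1 lies beyond the scatter, so compound 1 shows more inhibition at the dose given than compound 3.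

Compound 4 `COc1ccc(C2C(C)C(=O)CC(c3ccc(F)cc3)N2C(=O)CN2CCN(C)CC2)cc1` has not yet been measured in this assay. It differs from compound 3 in one place: 4-methylpiperazin-1-yl in place of chloro on a saturated chain carbon bound to a carbonyl carbon. Compound 1 and compound 2 both already carry a 4-methylpiperazin-1-yl on the chain carbon bound to the carbonyl carbon, and both gave numbers above that of compound 3, though only the gap to compound 1 exceeds the scatter.

Among the compounds with values here, no measured pair shows this exact change on an otherwise identical core, so the expected step rests only on what compound 1 and compound 2 show. A small upward step is expected, roughly a number 6.8 percentage points higher from compound 3 to compound 4 (within the scatter), and it may not exceed the scatter. Compound 4 is therefore expected to give about 58% in this assay, with a likely range from 44% to 72%.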

Compound 4, a percentage reported as inhibition, in the whole organism at one dose (the size of the read-out at that dose, not a potency): 55.2%
The estimate for compound 4 lay 2.8 percentage points above the measured number; the measured number falls inside the stated range.
By their numbers in this assay, from the lowest: compounds 3, 2 and 4 (each within the scatter of the next); then compound 1.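

In this assay, within the data shown here, 4-methylpiperazin-1-yl in place of chloro on a saturated chain carbon bound to a carbonyl carbon gives a number 4 percentage points higher from compound 3 to compound 4 (within the scatter), the first direct reading of this change on an otherwise identical core, and it does not separate the two compounds. Among these compounds, on an aromatic carbon, fluoro in place of chloro gives a number 2.1 percentage points higher from compound 2 to compound 4 (within the scatter), which also cannot be told apart from no change, whereas methoxy in place of chloro on an aromatic carbon gives a number 10.3 percentage points lower from compound 1 to compound 4 (beyond the scatter), the only one of these steps beyond the scatter. The compounds shown offer no separate measurement that bears on the reason for any of these steps.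

As far as these compounds go, it remains open whether another group on the chain carbon, such as morpholine or dimethylamino, or a longer chain between the carbonyl and the piperazine ring, would give a step beyond the scatter. The read-out also reports the size of the effect at one dose rather than a potency, so the standing of these compounds at other doses remains open.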